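Bromo to hydrogen step from compound 1 to compound 4

The compounds below may be only part of what the source reports. "The series", "measured", "known", "first", "only" and "open" are said of these compounds alone.

Measured in a functional assay on MCF7 cells (Homo sapiens) for inhibition, read by MTT assay, with a stated time of 48 h, tested at 7.5 ug/mL; on this read-out lower numbers stand for less inhibition of growth and higher numbers for more inhibition of growth at the one concentration tested:
compound 1 `O=c1cc(-c2ccccc2)oc2cc(N3COc4c(Br)cccc4C3)ccc12`: 2.21%
compound 2 `O=c1cc(-c2ccccc2)oc2ccc(N3COc4c(Br)cccc4C3)cc12`: "not active" (no number reported)
compound 3 `O=c1cc(-c2ccccc2)oc2cc(N3COc4c(Br)cc(Br)cc4C3)ccc12`: 1.48%

Compound 1 and compound 3 give numbers within the scatter of each other in this assay; for compound 2 only the word "not active" is reported and no number, so compound 1 cannot be set above or below it. The whole series sits at very low growth inhibition at the one concentration tested.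

Compound 4 `O=c1cc(-c2ccccc2)oc2cc(N3COc4ccccc4C3)ccc12` has not been measured. It differs from compound 1 by hydrogen in place of bromo on an aromatic carbon.

Among the compounds with values here, the only measured step that bears on a change of this kind is a number 0.7 percentage points lower from compound 1 to compound 3 (within the scatter), where a second bromo entered the same ring of the shared core and the number barely moved. Removing the remaining bromo is the reverse kind of change on the same ring, and with the two measured numbers already close to zero there is no room for a drop beyond the scatter and no measured sign of a rise. The expected step is therefore a number 0.2 percentage points lower from compound 1 to compound 4 (within the scatter), none beyond the scatter.

Compound 4 is estimated at 2%, with a range from -5% to 10%, and a fair chance that, as with compound 2, only "not active" is reported.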

Compound 4, percent growth inhibition at one concentration: 2.65%
Estimate against measurement, compound 4: 0.7 percentage points below; measured number inside the range.
By their numbers in this assay, from the lowest: compounds 3, 1 and 4 (each within the scatter of the next).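

In this assay, replacing bromo with hydrogen on this aromatic carbon gives a number 0.4 percentage points higher from compound 1 to compound 4 (within the scatter) and so leaves the read-out where it was. The earlier step, a number 0.7 percentage points lower from compound 1 to compound 3 (within the scatter), showed only that a second bromo on the same ring changed nothing beyond the scatter; this step tests the first bromo itself, and the series reading does not depend on that atom, since the form with no bromo at all sits at the same very low level of growth inhibition. No measurement at hand accounts for this flat reading, so the step can be recorded but not explained.

Bromo and hydrogen are the only two groups compared at this place, and both leave the number close to zero, so it remains open whether a group of a different kind there, such as an amine, a carboxylic acid or a longer chain, would move the number beyond the scatter. Also open, going by these compounds, is whether a change elsewhere on the shared core, for example a hydroxy group on its unfused phenyl ring, would lift the series out of this low range.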